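Methoxy for fluoro on the benzyl ring of compound 3

A few compounds are considered here, and "the series" means these few. Any claim that something is new, unique, unknown or untested is made for them only; others in the source may bear on it.

The series shares a core carrying a benzyloxy arm. Compound 1 `Oc1nc(OCc2ccccc2)c2nn[nH]c2n1` gives in an assay on isolated protein for inhibition of Myeloperoxidase (Homo sapiens), read by fluorescence, with stated times of 10 min, 30 s and 5 min (a higher number here means a weaker inhibitor, a lower number a stronger inhibitor), only a limit, > 13000 nM; this is the limit of > 13000 nM in this assay, at which 1 of the 3 values shown sits. Compound 2 `CCNc1nc(OCc2ccccc2)c2nn[nH]c2n1` gives 2900 nM, and the step of an at least 4.4-fold lower number from compound 1 to compound 2 (0.65 log units; beyond the scatter) sits at the far end of the core from the benzyl ring. Among the compounds with values here, compound 3 `Nc1nc(OCc2cccc(F)c2)c2nn[nH]c2n1` gives 40 nM, the lowest number so far, with compound 2 as its nearest neighbour on the scale. Compound 4 `COc1cccc(COc2nc(N)nc3[nH]nnc23)c1` carries methoxy in place of fluoro on an aromatic carbon. Within the data shown here, no measured step touches the benzyl ring, so the one measured step, an at least 4.4-fold lower number from compound 1 to compound 2 (0.65 log units; beyond the scatter), does not bear on this change. For compound 4 the expected step of a 1.5-fold higher number from compound 3 to compound 4 (0.18 log units; within the scatter) is none beyond the scatter. Compound 4 is estimated at 60 nM, ranging from 20 nM to 200 nM.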

Compound 4, half-maximal inhibitory concentration: 490 nM
Compound 4: the middle estimate sits 8.2-fold (0.91 log units) below what was measured; the measured number lies above the stated range.
By their numbers in this assay, from the lowest: compound 3; then compound 4; then compound 2. At a limit, above all of these: compound 1.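

The benzyl ring position is not indifferent to what it carries in this assay (a 12-fold higher number from compound 3 to compound 4 (1.09 log units; beyond the scatter)). Within the data shown here, this is the first measured step on that ring, and it shows that methoxy in place of fluoro, meta to a large group, can cost as much as a change at the far end of the core or more. Nothing at hand accounts for this step.

Still open, going by these compounds, is whether a chloro or a methyl at this place would stay close to compound 3 or fall towards compound 4. The shown compounds also leave open how a longer ether chain would behave here.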